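This account rests on a few compounds, and the source may have more. Where it says the series, first, only, none or still open, it means among the compounds named here.

Working notes on the hydroxyphenyl and methoxyphenyl triazole series.

Of the compounds shown here, three have been measured. Compound 2 `COc1ccccc1-c1cn(C[C@H](O)[C@H]2OC(=O)C(OCc3ccccc3)=C2OCc2ccccc2)nn1` gives 50 nM in an ADME assay on HFF cells (Homo sapiens) for cytotoxicity, read by MTT assay, with a stated time of 72 h; a lower number here means a stronger inhibitor, a higher number a weaker inhibitor. Compound 1 `O=C1O[C@H]([C@@H](O)Cn2cc(-c3cccc(O)c3)nn2)C(OCc2ccccc2)=C1OCc1ccccc1` gives 39000 nM in this assay. The two share their core and differ in one place: 3-hydroxyphenyl in place of 2-methoxyphenyl on an aromatic carbon. This change produced the step of a 780-fold higher number from compound 2 to compound 1 (2.89 log units; beyond the scatter).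

Compound 3 `COc1ccccc1-c1cn(C/C=C2\OC(=O)C(OCc3ccccc3)=C2OCc2ccccc2)nn1` is recorded only as a limit, > 100000 nM, in this assay. Of the three values, one sits at this limit (the limit of > 100000 nM in this assay, at which 1 of the 3 values shown sits). How the core of compound 3 differs from that of compound 2 is not broken down here.

Compound 4 `O=C1O/C(=C\Cn2cc(-c3cccc(O)c3)nn2)C(OCc2ccccc2)=C1OCc1ccccc1` is still to be measured in this assay. It relates to compound 3 by the same change that relates compound 1 to compound 2: 3-hydroxyphenyl in place of 2-methoxyphenyl on an aromatic carbon. The place of the change is the same in both pairs, so this is the same change made on a second core.

For compound 4 the step that the limit leaves unreadable from compound 3 to compound 4 is expected, resting on the earlier step of a 780-fold higher number from compound 2 to compound 1 (2.89 log units; beyond the scatter), where this change gave a markedly higher number. Since compound 3 already stands at a limit, the expectation for compound 4 is that the measurement in this assay will again be reported as a limit rather than a number. The estimate for compound 4 in this assay is 200000 nM, with a range from 60000 nM to 800000 nM.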

Compound 4, half-maximal inhibitory concentration: 42600 nM
Compound 4: middle estimate off by 4.7-fold (0.67 log units), on the high side; measured number below the stated range.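

In this assay, the change to 3-hydroxyphenyl in place of 2-methoxyphenyl does not carry over from one core to the other, and the two steps run in opposite directions: the same change on two cores in this assay, a 780-fold higher number (2.89 log units; beyond the scatter) from compound 2 to compound 1 and an at least 2.3-fold lower number (0.37 log units; beyond the scatter) from compound 3 to compound 4, at least 1800-fold (3.26 log units) apart, beyond the scatter of two such steps

The new step is an at least 2.3-fold lower number from compound 3 to compound 4 (0.37 log units; beyond the scatter), but compound 3 stands only at a limit, so this gives a minimum size for the step and not its true size: the limit of > 100000 nM in this assay, at which 1 of the 4 values shown sits.

The two pairs show that the outcome of this change in this series depends on the core it is made on, but they do not show which difference between the cores is responsible, and they give no rule for predicting the step on a third core.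

Open, going by these compounds, is how either core would respond to a 2-hydroxyphenyl or a 3-methoxyphenyl group, which would separate the identity of the substituent from its place on the ring. Also open, on these data alone, is how an amine or a carboxylic acid on that aromatic ring would read on the two cores, and where compound 3 would fall as a number rather than a limit.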